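A few compounds are considered here, and "the series" means these few. Any claim that something is new, unique, unknown or untested is made for them only; others in the source may bear on it.

Measured compounds:
compound 1 `CC(Oc1ccc(Oc2ccc(C(F)(F)F)cc2)cc1)C(=O)Cn1nnc(-c2ccc(Cl)cc2)n1` gives 9% in an ADME assay on S9 fraction from liver (Rattus norvegicus) for metabolic stability, read by LC-MS, using NADPH, with a stated time of 30 min; a higher number here means that more of the compound is left, a lower number that less of the compound is left;
compound 2 `CCCCCCCCc1ccc(OC(C)C(=O)Cn2nnc(-c3ccc(C(=O)O)cc3)n2)cc1` gives 55%;
compound 3 `CC(Oc1ccc(Oc2ccc(F)cc2)cc1)C(=O)Cn1nnc(-c2ccc(C(=O)O)cc2)n1` gives 33%.

Compound 3 stands second of the three in this assay, and both of its gaps lie beyond the scatter: compound 2 sits higher and compound 1 sits lower. Going by the values given here, the only step between two measured compounds that differ in one place is a number 22 percentage points lower from compound 2 to compound 3 (beyond the scatter), a modest fall when a 4-fluorophenoxy group replaces octyl on an aromatic carbon.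

Compound 4 `CC(Oc1ccc(Oc2ccc(C(F)(F)F)cc2)cc1)C(=O)Cn1nnc(-c2ccc(C(=O)O)cc2)n1` is the one that has not been measured. Its change from compound 3 is trifluoromethyl in place of fluoro on an aromatic carbon, that is, 4-fluorophenoxy becomes 4-(trifluoromethyl)phenoxy. Among the compounds with values here, no measured step matches this change directly. Compound 1 also carries a 4-(trifluoromethyl)phenoxy group but differs from compound 3 in a second place as well, so its low value can only hint at the direction. On this thin basis compound 4 is expected to fall by a number 8 percentage points lower from compound 3 to compound 4 (within the scatter) from compound 3, a step that may still lie within the scatter. The estimate for compound 4 is 25%, with a range from 10% to 45%.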

Compound 4, percent of the compound remaining: 36%
Compound 4: middle estimate off by 11 percentage points, on the low side; the measured number falls inside the stated range.
By their numbers in this assay, from the lowest: compound 1; then compounds 3 and 4 (each within the scatter of the next); then compound 2.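

In this assay, trifluoromethyl in place of fluoro on an aromatic carbon, para to a large group, gives a number 3 percentage points higher from compound 3 to compound 4 (within the scatter) and so leaves the two groups indistinguishable at this position. With 4-(trifluoromethyl)phenoxy in place of octyl there is a number 19 percentage points lower from compound 2 to compound 4 (beyond the scatter) in the same direction as the step seen with 4-fluorophenoxy, so the fall from compound 2 holds for both phenoxy groups. Carboxy in place of chloro on an aromatic carbon gives a number 27 percentage points higher from compound 1 to compound 4 (beyond the scatter) with trifluoromethyl present on both sides, which ties the low number of compound 1 to the chloro end rather than to the trifluoromethyl.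

On these data alone, whether an amine or a nitrile at the same place would also stay within the scatter remains open, as does whether the carboxy step holds alongside 4-fluorophenoxy. Nothing available accounts for any of these numbers.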